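Dimethylamino to diethylamino: what compound 4 may show

This account rests on a few compounds, and the source may have more. Where it says the series, first, only, none or still open, it means among the compounds named here.

Measured in an ADME assay on HEK293 cells (Homo sapiens) for cytotoxicity, read by MTT assay, with a stated time of 48 h; on this read-out lower numbers stand for stronger inhibition and higher numbers for weaker inhibition:
- Compound 1 `Cn1c(N)c(-c2nc3ccccc3[nH]2)c2nc(C#N)c(C#N)nc21`: > 50000 nM, a limit of the assay
- Compound 2 `CCn1c(N)c(-c2nc3ccccc3[nH]2)c2nc(C#N)c(C#N)nc21`: > 50000 nM, a limit of the assay
- Compound 3 `CN(C)CCn1c(N)c(-c2nc3ccccc3[nH]2)c2nc(C#N)c(C#N)nc21`: 9730 nM

Compound 3 is the only one of the three with a true number, and it stands clear of the limit of > 50000 nM in this assay, at which 2 of the 3 values shown sit. Compound 4 `CCN(CC)CCn1c(N)c(-c2nc3ccccc3[nH]2)c2nc(C#N)c(C#N)nc21` has not been measured yet. It differs from compound 3 as follows: diethylamino in place of dimethylamino on a saturated chain carbon, two bonds along the chain from an aromatic nitrogen. This puts diethylamino in place of dimethylamino on a saturated chain carbon, two bonds along the chain from an aromatic nitrogen.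

The closest measured change is an at least 5.1-fold lower number from compound 2 to compound 3 (0.71 log units; beyond the scatter), which introduced dimethylamino at that same place. The step of an at least 5.1-fold lower number from compound 1 to compound 3 (0.71 log units; beyond the scatter) reads alike, while a step that the two limits leave unreadable from compound 1 to compound 2 adds nothing. Both readable steps start from a limit, and neither swaps one amino group for another. The expected result in this assay is therefore a 1.4-fold lower number from compound 3 to compound 4 (0.14 log units; within the scatter), a slightly lower number and no step beyond the scatter. For compound 4 the estimate is 7000 nM, with an expected range of 3000 nM to 20000 nM.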

Compound 4, half-maximal inhibitory concentration: 12200 nM
The estimate for compound 4 lay 1.7-fold (0.24 log units) below the measured number, and the stated range covers the measured number.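

In this assay the new result is a 1.3-fold higher number from compound 3 to compound 4 (0.10 log units; within the scatter), so the read-out does not separate diethylamino from dimethylamino on this saturated chain carbon, two bonds along the chain from an aromatic nitrogen. Two amines now stand apart from the compounds without an amino group at this place: there is an at least 4.0-fold lower number from compound 2 to compound 4 (0.61 log units; beyond the scatter), and also an at least 4.0-fold lower number from compound 1 to compound 4 (0.61 log units; beyond the scatter). Compound 1 and compound 2 each stand at a limit of the assay, which leaves the step between them unreadable: the limit of > 50000 nM in this assay, at which 2 of the 4 values shown sit.

From the compounds shown here alone, whether a ring amine such as pyrrolidine or morpholine at this place would give a similar number stays open. So does the outcome for a longer chain carrying the dimethylamino group, or for a carboxylic acid in place of the amine.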